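The compounds below may be only part of what the source reports. "The series", "measured", "known", "first", "only" and "open" are said of these compounds alone.

Three compounds sharing one core have entries in an in vitro ADME assay on microsomes from liver (Homo sapiens) for metabolic stability; a higher number here means faster removal of the compound, a lower number slower removal. For compound 1 `O=C(COCc1ccccc1)N1CCN(c2ccccc2)CC1` the entry reads "not determined" (no result reported), so it offers no number to compare. Compound 2 `O=C(COCc1ccccc1)N1CCN(c2ccc(Cl)cc2)CC1` gives 290 mL.min-1.g-1, and compound 3 `O=C(COCc1ccccc1)N1CCN(c2ccc(Cl)cc2Cl)CC1` gives 450 mL.min-1.g-1. Within the data shown here, compound 3 therefore stands within the scatter of compound 2, the only other compound with a number.

Compound 4 `O=C(COCc1ccccc1)N1CCN(c2ccc(F)cc2F)CC1` has not yet been measured. It differs from compound 3 by 2,4-difluorophenyl in place of 2,4-dichlorophenyl on an amine nitrogen in a ring.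

Among the measured compounds shown here, the one measured step that bears on this change is chloro in place of hydrogen on an aromatic carbon, a 1.6-fold higher number from compound 2 to compound 3 (0.19 log units; within the scatter). For the measured compounds named here, it is only an indirect guide, since no measured compound carries the 2,4-difluorophenyl group and no step replaces one halogen with another. Going by the values given here, with so small a step as the sole precedent, only a slight shift towards a lower number in this assay is anticipated, and nothing beyond the scatter. The estimated change is a 1.7-fold lower number from compound 3 to compound 4 (0.22 log units; within the scatter). For compound 4 the expected value is 270 mL.min-1.g-1, with an estimated range from 130 mL.min-1.g-1 to 500 mL.min-1.g-1.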

Compound 4, intrinsic clearance in microsomes: 580 mL.min-1.g-1
Compound 4: middle estimate off by 2.1-fold (0.33 log units), on the low side; the measured number lies above the stated range.
By their numbers in this assay, from the lowest: compounds 2, 3 and 4 (each within the scatter of the next).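

In this assay, 2,4-difluorophenyl in place of 2,4-dichlorophenyl on the amine nitrogen in the ring gives a 1.3-fold higher number from compound 3 to compound 4 (0.11 log units; within the scatter), so this position now has a direct exchange of one halogen for another on record, and that exchange does not separate the two compounds. Set against the 4-chlorophenyl group, the same 2,4-difluorophenyl group gives a 2.0-fold higher number from compound 2 to compound 4 (0.30 log units; within the scatter), which means that compounds 2, 3 and 4 all lie within the scatter of one another, and the three halogenated phenyl groups shown cannot be ranked in this assay. Nothing available offers an explanation for these steps.

On these data alone, compound 1 gives "not determined" (no result reported), so the phenyl group without any halogen offers no number to set against these three, and what the halogens contribute at this position remains open. Also open, as far as these compounds go, is whether a different kind of group on this phenyl ring, such as a methoxy group or a nitrile, or a change at the other end of the shared core, would produce a step beyond the scatter.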